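Three Fluorinated Ethers and One Expected Value

The compounds below may be only part of what the source reports. "The series", "measured", "known", "first", "only" and "open" are said of these compounds alone.

Measured so far:
compound 1, `Cc1cc(COc2cccc(F)c2F)nc(-c2ccccn2)n1`, 398 nM
compound 2, `Cc1cc(COc2ccc(F)cc2F)nc(-c2ccccn2)n1`, 398 nM
compound 3, `Cc1cc(COc2cc(F)cc(F)c2F)nc(-c2ccccn2)n1`, 501 nM

In a functional assay on cells for antagonist activity at Free fatty acid receptor 1 (Homo sapiens), read by TR-FRET and inositol phosphate accumulation, with a stated time of 2 h (on this read-out lower numbers stand for stronger inhibition and higher numbers for weaker inhibition), compound 1 and compound 2 stand level at the digits printed, and compound 3 is close to both. The difference between the cores of compound 1 and compound 2 is not broken down here. From compound 1 to compound 3 the change is fluoro in place of hydrogen on an aromatic carbon, and it gave a 1.3-fold higher number from compound 1 to compound 3 (0.10 log units; within the scatter). Compound 4, `Cc1cc(COc2c(F)cc(F)cc2F)nc(-c2ccccn2)n1`, has not been measured. It differs from compound 2 by fluoro in place of hydrogen on an aromatic carbon. This is the same kind of change as from compound 1 to compound 3, but the surroundings differ: in compound 3 the new fluoro sits meta to a fluoro group, meta to a large group and para to a fluoro group, whereas in compound 4 it sits ortho to a large group and meta to two fluoro groups. Because the earlier step was a 1.3-fold higher number from compound 1 to compound 3 (0.10 log units; within the scatter), a similar step, a 1.3-fold higher number from compound 2 to compound 4 (0.10 log units; within the scatter), is expected here. Compound 4 is therefore estimated at 500 nM in this assay, within 250 nM to 1000 nM.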

Compound 4, half-maximal inhibitory concentration: 1260 nM
The estimate for compound 4 lay 2.5-fold (0.40 log units) below the measured number; the measured number lies above the stated range.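

In this assay, fluoro in place of hydrogen on an aromatic carbon, ortho to a large group and meta to two fluoro groups, gave a 3.2-fold higher number from compound 2 to compound 4 (0.50 log units; beyond the scatter). Set beside the same change on the other core, the two steps cannot be told apart: the same change on two cores in this assay, a 1.3-fold higher number (0.10 log units; within the scatter) from compound 1 to compound 3 and a 3.2-fold higher number (0.50 log units; beyond the scatter) from compound 2 to compound 4, 2.5-fold (0.40 log units) apart, within the scatter of two such steps. The pair therefore does not show that the change keeps its size from one core to another, nor that its size depends on the core, and two steps are too few to settle either point.

All the compounds shown carry only fluoro groups on this ring. Going by these compounds, how chloro, methoxy or a nitrile would read in their place remains open, as does the effect of an amine or a carboxylic acid there.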